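A few compounds are considered here, and "the series" means these few. Any claim that something is new, unique, unknown or untested is made for them only; others in the source may bear on it.

Measured in an ADME assay on HEL cells (Homo sapiens) for cytotoxicity, with a stated time of 3 days; on this read-out higher numbers stand for lower toxicity in this test and lower numbers for higher toxicity in this test:

- compound 1 `Cc1cn([C@@H]2O[C@H](CO[Si](C)(C)C(C)(C)C)[C@@]3(OS(=O)(=O)C=C3NC(=O)NC(=O)c3ccccc3)[C@H]2O[Si](C)(C)C(C)(C)C)c(=O)n(C)c1=O`: >= 80000 nM, a limit of the assay
- compound 2 `Cc1cn([C@@H]2O[C@H](CO)[C@@]3(OS(=O)(=O)C=C3NC(=O)NC(=O)c3ccccc3)[C@H]2O)c(=O)n(C)c1=O`: 100000 nM
- compound 3 `Cc1cn([C@@H]2O[C@H](CO[Si](C)(C)C(C)(C)C)[C@@]3(OS(=O)(=O)C=C3NC(=O)NC(=O)c3ccccc3)[C@H]2O)c(=O)n(C)c1=O`: > 100000 nM, a limit of the assay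

Compound 3 stands at a limit of this assay, not at a number; among the three values shown, one further value is also a limit, so the series is read through the limit of > 100000 nM in this assay, at which 1 of the 3 values shown sits, and the limit of >= 80000 nM in this assay, at which 1 of the 3 values shown sits, rather than through numbers. The two measured steps that reach compound 3 give little to hold onto: a step that the two limits leave unreadable from compound 1 to compound 3, and a number no lower from compound 2 to compound 3 (the limit leaves the size open). Neither fixes a size.

Compound 4 `Cc1cn([C@@H]2O[C@H](COC(=O)c3ccccc3)[C@@]3(OS(=O)(=O)C=C3NC(=O)NC(=O)c3ccccc3)[C@H]2O)c(=O)n(C)c1=O` differs from compound 3 by a group of 8 heavy atoms (7 carbon, 1 oxygen; one six-membered aromatic ring of carbon only) in place of a group of 7 heavy atoms (6 carbon, 1 silicon; no ring), on an oxygen on a saturated carbon. For the measured compounds named here, both measured steps sit at this same oxygen on a saturated carbon, and both leave the size open, so there is no measured step of readable size to carry over. With all three measured values at or near the top of the range, the expectation for compound 4 is a step of no size beyond the scatter, a number no higher from compound 3 to compound 4 (the limit leaves the size open), most likely reported again as a limit. Compound 4 is therefore estimated at 100000 nM, within 50000 nM to 200000 nM.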

Compound 4, minimum cytotoxic concentration: > 100000 nM
Compound 4 was reported as a limit; the forecaster's own chance of this, stated with the estimate: 75%; the middle value lies on the limit itself.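

In this assay compound 4 gives > 100000 nM as a limit of the assay. Benzoyl in place of hydrogen on this oxygen on a saturated carbon gives a number no lower from compound 2 to compound 4 (the limit leaves the size open) and so adds a group with a six-membered aromatic ring to those that leave the read-out at the top of its range. The step between the two limits cannot be read, and the series is now read mainly through a limit: the limit of > 100000 nM in this assay, at which 2 of the 4 values shown sit.

The compounds shown leave open whether any group on this oxygen lowers the minimum cytotoxic concentration, and how far the limits hide differences among the groups present. An amine or a carboxylic acid here in place of benzoyl would show whether the top of the range holds beyond these groups.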